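Working notes on the step from compound 3 to compound 4

The compounds below may be only part of what the source reports. "The series", "measured", "known", "first", "only" and "open" are said of these compounds alone.

Of the compounds shown here, three on the shared core have been measured: compound 1 `Cc1c(C(N)=O)sc2nc(NN)n(Cc3ccccc3)c(=O)c12`, compound 2 `Cc1c(C(N)=O)sc2nc(N/N=C/c3ccc(Br)cc3)n(Cc3ccccc3)c(=O)c12` and compound 3 `Cc1cc(C)n(-c2nc3sc(C(N)=O)c(C)c3c(=O)n2Cc2ccccc2)n1`. In a functional assay on the whole organism (strain albino) for inhibition, with Rattus norvegicus as the target, read by paw edema, in the formalin test, with stated times of 1 h and 2 h, at a dose of 10 mg/kg by the oral route (a lower number here means less inhibition, a higher number more inhibition at the dose given (going by the name of the read-out)), compound 1 gives 61%, compound 2 gives 39% and compound 3 gives 39%. Compound 3 thus stands level with compound 2 at the digits reported, and the two together are the lowest of the three numbers; only compound 1 lies apart from them, as the step of a number 22 percentage points lower from compound 1 to compound 3 (beyond the scatter) shows. The two moves away from the aminoamino compound 1 are of the same size, a number 22 percentage points lower from compound 1 to compound 2 (beyond the scatter) and a number 22 percentage points lower from compound 1 to compound 3 (beyond the scatter), while the exchange of one ring group for another on the same aromatic carbon, no change at the digits printed from compound 2 to compound 3 (within the scatter), left the number where it was.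

Compound 4 `CC1=NN(c2nc3sc(C(N)=O)c(C)c3c(=O)n2Cc2ccccc2)C(=O)C1` is the next member. Against compound 3 the change is a group of 7 heavy atoms (4 carbon, 2 nitrogen, 1 oxygen; one five-membered non-aromatic ring with 2 hetero atoms) in place of a group of 7 heavy atoms (5 carbon, 2 nitrogen; one five-membered aromatic ring with 2 hetero atoms), on an aromatic carbon. The step that bears most directly on it is no change at the digits printed from compound 2 to compound 3 (within the scatter), since that too swapped one ring group for another at this carbon with no movement beyond the scatter, so for compound 4 no step beyond the scatter is expected, a number 1 percentage points higher from compound 3 to compound 4 (within the scatter). Compound 4 is therefore estimated to give 40%, within a range from 28% to 52%.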

Compound 4, a percentage reported as inhibition, in the whole organism at one dose (the size of the read-out at that dose, not a potency): 48%
Estimate against measurement, compound 4: 8 percentage points below; measured number inside the range.
By their numbers in this assay, from the lowest: compounds 2, 3 and 4 (each within the scatter of the next); then compound 1.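

At the aromatic carbon between two ring nitrogen atoms, a five-membered non-aromatic ring with 2 hetero atoms can take the place of 3,5-dimethyl-1H-pyrazol-1-yl in this assay without a step beyond the scatter, as a number 9 percentage points higher from compound 3 to compound 4 (within the scatter) shows, so an aromatic ring at this carbon is not required for a number in this band. The comparison with the larger bromine-bearing group gives the same reading, with a number 9 percentage points higher from compound 2 to compound 4 (within the scatter), while a number 13 percentage points lower from compound 1 to compound 4 (beyond the scatter) keeps the aminoamino compound apart from all three compounds with larger groups here, now including one with a non-aromatic ring. No measurement available bears on the reason for these numbers.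

The compounds shown leave open whether another small group at this carbon, such as a plain amine or a methoxy group, would stand with compound 1 or with compounds 2, 3 and 4. They also leave open whether the separation of compound 1 from the other three would hold at other doses, since this assay gives a single-dose read-out and not a potency.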